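A few compounds are considered here, and "the series" means these few. Any claim that something is new, unique, unknown or untested is made for them only; others in the source may bear on it.

Measured so far in a functional assay on HeLa cells (Homo sapiens) for cytotoxicity, read by MTT assay, with a stated time of 48 h; a higher number here means a weaker inhibitor, a lower number a stronger inhibitor:
compound 1, `C#CCN1CCN(CC(=O)N2CCN(c3ccc(C(=O)c4cc5ccc(N(CC)CC)cc5o4)cc3)CC2)CC1`, gives > 40000 nM.
compound 2, `CCN(CC)c1ccc2cc(C(=O)c3ccc(N4CCN(C(=O)CN5CCN(Cc6ccc(C(F)(F)F)cc6)CC5)CC4)cc3)oc2c1`, gives > 40000 nM.

Compound 2 stands at the edge of this assay: the value > 40000 nM reported for compound 2 is a limit, not a number. Both values shown sit at the limit of > 40000 nM in this assay, at which 2 of the 2 values shown sit. Among the compounds with values here, the one step that touches compound 2, a step that the two limits leave unreadable from compound 1 to compound 2, cannot be read in size, since it runs between two limits.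

Compound 3, `CCN(CC)c1ccc2cc(C(=O)c3ccc(N4CCN(C(=O)CN5CCN(CC(C)=O)CC5)CC4)cc3)oc2c1`, differs from compound 2 by acetyl in place of 4-(trifluoromethyl)phenyl on a saturated chain carbon bound to an amine nitrogen in a ring. Within the data shown here, no measured step bears on this change in a readable way: the only step at this place of the shared core, a step that the two limits leave unreadable from compound 1 to compound 2, is unreadable. The expectation for compound 3 in this assay therefore rests only on where compound 2 stands. Compound 3 is expected to give 40000 nM, with a range of 15000 nM to 120000 nM, most likely again as a limit. The step of a number no higher from compound 2 to compound 3 (the limit leaves the size open) is accordingly expected to be none beyond the scatter.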

Compound 3, half-maximal inhibitory concentration: 2760 nM
The estimate for compound 3 lay 14-fold (1.16 log units) above the measured number; measured number outside the range, below it.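

In this assay, this place on a saturated chain carbon bound to an amine nitrogen in a ring is now shown to govern the read-out: acetyl in place of 4-(trifluoromethyl)phenyl gives an at least 14-fold lower number from compound 2 to compound 3 (1.16 log units; beyond the scatter), and acetyl in place of ethynyl gives an at least 14-fold lower number from compound 1 to compound 3 (1.16 log units; beyond the scatter). The shared core alone therefore does not hold the series at the limit, and the group at this place decides whether a number can be read at all. Compound 1 and compound 2 each stand at a limit, not at a number, so both steps stay open in size: the limit of > 40000 nM in this assay, at which 2 of the 3 values shown sit.

On these data alone, whether the carbonyl of 2-oxopropyl is needed stays open, as a plain propyl chain or a 2-hydroxypropyl group at this place would test it. Within the data shown here, with compound 3 the only one giving a number, no trend across groups can be stated.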